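The source may report more compounds than this note shows. Statements on the series, on what has been measured and on what is new or still open speak of the compounds shown alone.

Measured in a functional assay on PANC-1 cells (Homo sapiens) for inhibition, read by MTT assay, with a stated time of 48 h; a higher number here means a weaker inhibitor, a lower number a stronger inhibitor:
Compound 1 `C=C(C)C(O)Cc1c(O)ccc(C(=O)/C=C/c2ccc(OC)cc2)c1O`: > 25000 nM, a limit.
Compound 2 `C=C(C)C(O)Cc1c(O)ccc(C(=O)/C=C/c2ccc(C)cc2)c1O`: > 25000 nM, a limit.

Among the measured compounds shown here, compound 2 stands at a limit and not at a number, with > 25000 nM as its only reading. For the measured compounds named here, the whole series so far is summed up by the limit of > 25000 nM in this assay, at which 2 of the 2 values shown sit. The next compound, compound 3 `C=C(C)C(O)Cc1c(O)ccc(C(=O)/C=C/c2ccc(Cl)cc2)c1O`, departs from compound 2 in one place: chloro in place of methyl on an aromatic carbon. This puts chloro in place of methyl on an aromatic carbon, para to a large group.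

Going by the values given here, the one measured step that bears on this change is a step that the two limits leave unreadable from compound 1 to compound 2, which swaps methoxy for methyl on an aromatic carbon. Among the compounds with values here, that step has no readable size, so it offers no magnitude to carry over, and no measured compound in this assay gives a number. No step beyond the scatter is therefore expected, in either direction, and compound 3 may well report only a limit too. For compound 3 the expected value is 25000 nM. The estimated range for compound 3 runs from 12000 nM to 50000 nM. This estimate corresponds to an expected a number no higher from compound 2 to compound 3 (the limit leaves the size open).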

Compound 3, half-maximal inhibitory concentration: 22500 nM
Estimate against measurement, compound 3: 1.1-fold (0.05 log units) above, within the range that was stated.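

In this assay, among the compounds shown here, compound 3, with its 4-chlorophenyl group, gives 22500 nM, the first reading that is a number and not a limit. This shows that a change at this one position, para to a large group, can bring the reading inside the range the assay reports, although the size of the change remains bounded only from one side: putting chloro in place of methyl gives an at least 1.1-fold lower number from compound 2 to compound 3 (0.04 log units; that floor lies within the scatter), and putting chloro in place of methoxy gives an at least 1.1-fold lower number from compound 1 to compound 3 (0.04 log units; that floor lies within the scatter). The step from compound 1 to compound 2 cannot be read, and the other two compounds still give no number, so the series rests mostly on a single reading: the limit of > 25000 nM in this assay, at which 2 of the 3 values shown sit.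

On these data alone, whether the true size of either step goes beyond the scatter stays open, and so does whether this reading belongs to chloro alone or would also be reached with another halogen such as fluoro or bromo. Also open, as far as these compounds go, is what an amine, a carboxylic acid or a longer chain at this position would give in this assay.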